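Trimming the Amine Tail of a Benzazepinone Tetrazole Series

The source may report more compounds than this note shows. Statements on the series, on what has been measured and on what is new or still open speak of the compounds shown alone.

Of the compounds shown here, three built on a shared core have been measured in a functional assay (Pituitary gland cell) with Rattus norvegicus as the target; on this read-out higher numbers stand for an effect only at larger amounts of compound and lower numbers for an effect already at smaller amounts. Compound 1 `CC(C)(CC(=O)N[C@@H]1CCc2ccccc2N(Cc2ccc(-c3ccccc3-c3nn[nH]n3)cc2)C1=O)NCCO` gives 30 nM. Compound 2 `CC(C)[C@H](O)CNC(C)(C)CC(=O)N[C@@H]1CCc2ccccc2N(Cc2ccc(-c3ccccc3-c3nn[nH]n3)cc2)C1=O` gives 1000 nM, which is a 33-fold higher number from compound 1 to compound 2 (1.52 log units; beyond the scatter). Compound 3 `CC(C)(CC(=O)N[C@@H]1CCc2ccccc2N(Cc2ccc(-c3ccccc3-c3nn[nH]n3)cc2)C1=O)NC[C@H](O)CO` gives 10 nM, the lowest of the three numbers, a 3.0-fold lower number from compound 1 to compound 3 (0.48 log units; beyond the scatter) and a 100-fold lower number from compound 2 to compound 3 (2.00 log units; beyond the scatter).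

Compound 4 `CC(C)(N)C(=O)N[C@@H]1CCc2ccccc2N(Cc2ccc(-c3ccccc3-c3nn[nH]n3)cc2)C1=O` has not yet been measured in this assay. It carries 1-amino-1-methylethyl in place of 2-((2,3-dihydroxypropyl)amino)-2-methylpropyl on a carbonyl carbon, so the whole dihydroxypropylamine side arm disappears and only a short amine remains at the carbonyl. Within the data shown here, none of the measured steps removes this arm outright; they only vary its far end, where a small hydroxymethyl brought a modest gain and an isopropyl a large loss. The loss of the hydroxylated chain that gave compound 3 its low number is therefore expected to cost potency, and the step of a 15-fold higher number from compound 3 to compound 4 (1.18 log units; beyond the scatter) is estimated to be a clear rise. Compound 4 is expected to give about 150 nM, in a range from 25 nM to 800 nM.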

Compound 4, concentration for half-maximal effect: 30 nM
Estimate against measurement, compound 4: 5.0-fold (0.70 log units) above; low and high end bracket the measured number.
By their numbers in this assay, from the lowest: compound 3; then compounds 1 and 4 (each within the scatter of the next); then compound 2.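

In this assay, cutting the side arm back to 1-amino-1-methylethyl on the carbonyl carbon gives only a 3.0-fold higher number from compound 3 to compound 4 (0.48 log units; beyond the scatter), so most of the 2-((2,3-dihydroxypropyl)amino)-2-methylpropyl arm can go at a modest price. The short group and the hydroxyethyl-bearing arm cannot be told apart (no change at the digits printed from compound 1 to compound 4 (within the scatter)), while the short group sits far from the arm with the isopropyl end (a 33-fold lower number from compound 2 to compound 4 (1.52 log units; beyond the scatter)), which shows that the large penalty of compound 2 comes with that longer arm and is not shared by the short one. No measurement given here accounts for these differences.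

The compounds shown leave open whether the amine of the short group is needed at all, as a hydroxyl or a carboxylic acid in its place would test. They also leave open whether a 2,3-dihydroxypropyl group placed directly on that short amine would recover the remaining gap.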